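Estimating an unmeasured spirocyclic analogue in a breast cancer cell assay

This account rests on a few compounds, and the source may have more. Where it says the series, first, only, none or still open, it means among the compounds named here.

Measured compounds:
compound 1 `CCOc1ccc(N2C(=O)[C@@]3(NC2=S)C(c2ccc(Cl)cc2)CN(C)[C@]32C(=O)Nc3ccccc32)cc1` gives 87700 nM
compound 2 `CC(C)Oc1ccc(C2CN(C)[C@]3(C(=O)Nc4ccccc43)[C@]23NC(=S)N(c2ccc(F)c(Cl)c2)C3=O)cc1` gives 20200 nM
compound 3 `CCOc1ccc(N2C(=O)[C@@]3(NC2=S)C(c2ccc(Cl)cc2)CN(C)[C@]32C(=O)Nc3ccc(Br)cc32)cc1` gives 34900 nM

All three numbers come from a functional assay on MCF7 cells (Homo sapiens) for cytotoxicity, read by MTT assay, with a stated time of 48 h; on this read-out lower numbers stand for stronger inhibition and higher numbers for weaker inhibition. Among them compound 2 stands lowest, although its gap to compound 3 lies within the scatter; only its gap to compound 1 is clearly beyond it. Compound 4 `CCc1ccc(C2CN(C)[C@]3(C(=O)Nc4ccccc43)[C@]23NC(=S)N(c2ccc(F)c(Cl)c2)C3=O)cc1` has not yet been tested. It differs from compound 2 in one place: ethyl in place of isopropoxy on an aromatic carbon. The change sits on an aromatic carbon of a six-membered aromatic ring of carbon only.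

Within the data shown here, the only measured single step is a 2.5-fold lower number from compound 1 to compound 3 (0.40 log units; beyond the scatter), and it concerns a different ring of the shared core, so it does not bear on the change from compound 2 to compound 4. Compound 1 and compound 2 differ in more than one place, so their values give no clean reading either. With nothing that speaks directly to this change, the expected step in this assay is small and the direction uncertain. Compound 4 is therefore estimated at 30000 nM, with a range from 10000 nM to 90000 nM, which means an expected step of a 1.5-fold higher number from compound 2 to compound 4 (0.17 log units; within the scatter).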

Compound 4, half-maximal inhibitory concentration: 19000 nM
Compound 4: the middle estimate sits 1.6-fold (0.20 log units) above what was measured; the range from low to high includes it.
By their numbers in this assay, from the lowest: compounds 4, 2 and 3 (each within the scatter of the next); then compound 1.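

In this assay, ethyl in place of isopropoxy gives a 1.1-fold lower number from compound 2 to compound 4 (0.03 log units; within the scatter). Among these compounds, this is the first reading at this position, on an aromatic carbon para to a large group, and it shows that for this pair the oxygen can go and the substituent can shrink from 4 heavy atoms to 2 with no change that the assay can distinguish from scatter. Nothing measured here accounts for this result, so it stands as an observation only.

Going by these compounds, it remains open whether an amine, a carboxylic acid or a longer chain at this position would also leave the number in place. The compounds shown also leave open whether the swap from 4-isopropoxyphenyl to 4-ethylphenyl would read the same with other groups elsewhere on the shared core.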